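Quinolinone-benzimidazole series: removing a methyl, cytotoxicity unchanged so far

A few compounds are considered here, and "the series" means these few. Any claim that something is new, unique, unknown or untested is made for them only; others in the source may bear on it.

Compound 1 `Cc1ccc2[nH]c(=O)c(-c3nc4cc([N+](=O)[O-])ccc4[nH]3)cc2c1` and compound 3 `Cc1ccc2[nH]c(=O)c(-c3nc4cc(C)c(C)cc4[nH]3)cc2c1` share a core; the difference between the two cores is not broken down here. In a functional assay on SK-OV-3 cells (Homo sapiens) for cytotoxicity, read by MTT assay, with a stated time of 48 h (on this read-out higher numbers stand for weaker inhibition and lower numbers for stronger inhibition), compound 1 gives only a limit, > 100000 nM. Compound 2 `O=c1[nH]c2ccccc2cc1-c1nc2cc([N+](=O)[O-])ccc2[nH]1` arises from compound 1 by hydrogen in place of methyl on an aromatic carbon. In this assay compound 2 likewise gives only a limit, > 100000 nM. The step that the two limits leave unreadable from compound 1 to compound 2 is therefore unreadable, since the limit of > 100000 nM in this assay, at which 3 of the 3 values shown sit, holds both ends of it. In this assay compound 3 also gives only a limit, > 100000 nM.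

Compound 4 `Cc1cc2nc(-c3cc4ccccc4[nH]c3=O)[nH]c2cc1C` is not yet measured; it arises from compound 3 by hydrogen in place of methyl on an aromatic carbon, the same change as that from compound 1 to compound 2, at a place described in the same words. Because the limit of > 100000 nM in this assay, at which 3 of the 3 values shown sit, is where all three measured values sit, the step that the limit leaves unreadable from compound 3 to compound 4 is expected to stay unreadable as well, with compound 4 most likely returning a limit rather than a number. For compound 4 in this assay the expected value is 150000 nM, in a range from 60000 nM to 500000 nM.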

Compound 4, half-maximal inhibitory concentration: > 100000 nM
Compound 4 was reported as a limit (the forecaster's own chance of this, stated with the estimate: 85%); the middle value does not contradict the limit.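

No new step can be read, as compound 3 and compound 4 each give only a limit in this assay, and the step between them stays unreadable: the limit of > 100000 nM in this assay, at which 4 of the 4 values shown sit.

The compounds shown leave open whether hydrogen in place of methyl on an aromatic carbon changes cytotoxicity at all, and whether any compound of this series gives a number rather than a limit.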